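Cyclopentyl replaces isopentyl on the sulfur of compound 3

This account rests on a few compounds, and the source may have more. Where it says the series, first, only, none or still open, it means among the compounds named here.

Three measured compounds share one core and differ only in the group carried on the sulfur. Compound 1 `Cn1c(=O)c2c(nc(Sc3ccccc3)n2C)n(C)c1=O` gives 56400 nM in an assay on isolated protein for inhibition of Amine oxidase [flavin-containing] A (Homo sapiens), read by fluorescence; a higher number here means a weaker inhibitor, a lower number a stronger inhibitor. Compound 2 `Cn1c(=O)c2c(nc(SCc3ccc(Cl)cc3)n2C)n(C)c1=O` gives 2770 nM. Compound 3 `CC(C)CCSc1nc2c(c(=O)n(C)c(=O)n2C)n1C` gives 15200 nM, the second highest of the three numbers, and the steps of a 3.7-fold lower number from compound 1 to compound 3 (0.57 log units; beyond the scatter) and a 5.5-fold higher number from compound 2 to compound 3 (0.74 log units; beyond the scatter) place it between the other two. Compound 4 `Cn1c(=O)c2c(nc(SC3CCCC3)n2C)n(C)c1=O` carries cyclopentyl in place of isopentyl on a sulfur. Neither measured step swaps one saturated group for another of like size, so they offer only loose guidance, showing that the group on the sulfur moves the number by modest amounts. The change keeps the same number of heavy atoms, and the step of a 1.3-fold lower number from compound 3 to compound 4 (0.10 log units; within the scatter) is expected to stay within the scatter. Compound 4 is therefore estimated at 12000 nM, with a range from 5000 nM to 30000 nM.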

Compound 4, half-maximal inhibitory concentration: 9400 nM
For compound 4 the middle estimate is 1.3-fold (0.11 log units) above the measured one, within the range that was stated.
By their numbers in this assay, from the lowest: compound 2; then compounds 4 and 3 (each within the scatter of the next); then compound 1.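

The step to a ring on the sulfur reads a 1.6-fold lower number from compound 3 to compound 4 (0.21 log units; within the scatter), so in this assay the open isopentyl chain and the cyclopentyl ring, with the same count of carbons, cannot be told apart. Set against the phenyl on the same sulfur, cyclopentyl gives a 6.0-fold lower number from compound 1 to compound 4 (0.78 log units; beyond the scatter), so a saturated ring and this aromatic ring can be told apart. No available measurement explains either result. Still open, on these data alone, is how a larger saturated ring such as cyclohexyl, or a ring containing an amine such as piperidinyl, would compare on this sulfur.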